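This account rests on a few compounds, and the source may have more. Where it says the series, first, only, none or still open, it means among the compounds named here.

For the measured compounds named here, compound 1, with the structure `CO[C@@H]1CC=C2NN(c3ccc(C)cc3)C(=O)C[C@]2(C)O1`, was tested in a functional assay on A549 cells (Homo sapiens) for inhibition, read by sulforhodamine B assay, with a stated time of 48 h (a higher number here means a weaker inhibitor, a lower number a stronger inhibitor), and gave 21500 nM, the highest of the three numbers measured so far. Compound 3, `COc1cc(OC)cc(N2NC3=CC[C@@H](OC)O[C@@]3(c3ccccc3)CC2=O)c1`, gave 17300 nM in this assay, a result that lies within the scatter of that of compound 1, so the two cannot be told apart. Going by the values given here, compound 2, `CO[C@@H]1CC=C2NN(c3ccc(C)cc3)C(=O)C[C@]2(c2ccncc2)O1`, gave 5900 nM in this assay; the only single-point comparison available is a 3.6-fold lower number from compound 1 to compound 2 (0.56 log units; beyond the scatter), which arises from pyridin-4-yl in place of methyl on a saturated ring carbon.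

Compound 4, `CO[C@@H]1CC=C2NN(c3cccnc3)C(=O)C[C@]2(C)O1`, has not yet been measured. It differs from compound 1 as follows: pyridin-3-yl in place of 4-methylphenyl on an amide-type nitrogen in a ring. Among the compounds with values here, this change sits on the amide-type nitrogen of the shared core, a different site from the one varied between compound 1 and compound 2, so that step does not bear directly on it. Compound 3 carries a different aromatic group on the same nitrogen, but it also differs from compound 1 elsewhere, and its value is within scatter of compound 1. Within the data shown here, no measured step therefore speaks to this exchange, and no step beyond the scatter is expected. Compound 4 is estimated to give 20000 nM in this assay, within 8000 nM to 50000 nM, which would mean a 1.1-fold lower number from compound 1 to compound 4 (0.03 log units; within the scatter).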

Compound 4, half-maximal inhibitory concentration: 14400 nM
For compound 4 the middle estimate is 1.4-fold (0.14 log units) above the measured one; the range from low to high includes it.
By their numbers in this assay, from the lowest: compound 2; then compounds 4, 3 and 1 (each within the scatter of the next).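

In this assay, for the compounds shown here, the first single-change reading at the amide-type nitrogen of the shared core comes from putting pyridin-3-yl in place of 4-methylphenyl, which gives a 1.5-fold lower number from compound 1 to compound 4 (0.17 log units; within the scatter). The ring that enters has a ring nitrogen counted as a hydrogen-bond acceptor, which the carbon-only ring that leaves lacks, yet this exchange cannot be told apart from repeat-measurement scatter, so for this one pair the position tolerates the swap without a clear gain or loss. Nothing measured here offers an explanation for this result.

Going by these compounds alone, with only one exchange to read at this nitrogen, it remains open whether a group of a different kind there, such as a phenyl ring bearing a carboxylic acid or an amine on a longer chain, would move the number beyond the scatter. Also open, going by these compounds, is whether pyridin-3-yl on this nitrogen would give a similar step when joined with the pyridin-4-yl group of compound 2, which gives 5900 nM in the same assay.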